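Three Amides Measured, a Fourth Awaited

The source may hold more compounds than are shown below. What is called first, only, known or untested is meant among the compounds shown, and "the series" means these compounds.

The measured compounds and their numbers in a functional assay on HeLa cells (Homo sapiens) for antiproliferative activity, read by CCK-8 assay, with a stated time of 72 h; a lower number here means a stronger inhibitor, a higher number a weaker inhibitor:
- compound 1 `O=C(Nc1cccc(-c2oc3cc(-c4ccc(F)cc4)ccc3c(=O)c2O)c1)c1ccc(Cl)cc1` gives 3670 nM
- compound 2 `O=C(Nc1cccc(-c2oc3cc(-c4ccc(F)cc4)ccc3c(=O)c2O)c1)c1ccc(C(F)(F)F)cc1` gives 17400 nM
- compound 3 `O=C(Nc1cccc(-c2oc3cc(-c4ccc(F)cc4)ccc3c(=O)c2O)c1)c1cccc(F)c1` gives 8780 nM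

Among these three, compound 2 carries the highest number in this assay. Its nearest neighbour is compound 3, with a 2.0-fold lower number from compound 2 to compound 3 (0.30 log units; within the scatter), a gap that stays within the scatter. The furthest is compound 1, reached by a 4.7-fold higher number from compound 1 to compound 2 (0.68 log units; beyond the scatter), which lies beyond the scatter.

The unmeasured compound 4 `Cc1cc(C(=O)Nc2cccc(-c3oc4cc(-c5ccc(F)cc5)ccc4c(=O)c3O)c2)ccc1F` differs from compound 2 by 4-fluoro-3-methylphenyl in place of 4-(trifluoromethyl)phenyl on a carbonyl carbon. For the measured compounds named here, two measured steps bear on this. Leaving trifluoromethyl for chloro gives a 4.7-fold higher number from compound 1 to compound 2 (0.68 log units; beyond the scatter) read in reverse, a modest lowering; swapping the whole ring for 3-fluorophenyl gives a 2.0-fold lower number from compound 2 to compound 3 (0.30 log units; within the scatter), which is within the scatter. Replacing trifluoromethyl with a fluoro and methyl pair therefore points to a lower number for compound 4 in this assay, of modest size, with the possibility that the change stays within the scatter.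

For compound 4 the expected number in this assay is 6500 nM, with a range from 2500 nM to 16000 nM, which would mean an estimated step of a 2.7-fold lower number from compound 2 to compound 4 (0.43 log units; beyond the scatter).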

Compound 4, half-maximal inhibitory concentration: 18900 nM
Beside the measured number, compound 4's estimate is 2.9-fold (0.46 log units) below it, outside the stated range (above it).
By their numbers in this assay, from the lowest: compound 1; then compounds 3, 2 and 4 (each within the scatter of the next, the first and the last beyond it).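

In this assay, the step to 4-fluoro-3-methylphenyl on the carbonyl carbon gives a 1.1-fold higher number from compound 2 to compound 4 (0.04 log units; within the scatter), so this ring, with its fluoro and methyl groups, cannot be told apart from 4-(trifluoromethyl)phenyl at this position, and the lower number seen with 4-chlorophenyl is not shared by this replacement. Compound 4 also separates from the other two amides, with a 2.2-fold higher number from compound 3 to compound 4 (0.33 log units; beyond the scatter) and a 5.1-fold higher number from compound 1 to compound 4 (0.71 log units; beyond the scatter), which leaves compound 1 with the lowest number of the four and places 4-fluoro-3-methylphenyl with 4-(trifluoromethyl)phenyl at the weak end of the set. Nothing shown here offers an explanation for these differences.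

The compounds shown leave open whether any other group on this carbonyl carbon can bring the number below that of compound 1, at 3670 nM in this assay, for instance a phenyl ring bearing an amine or a carboxylic acid, or a longer chain in place of the ring. All four amides also share one core, so they cannot tell whether the same order of these rings would hold on a different core.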